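Chlorophenyl for Nitrophenyl in a Cytotoxicity Test

A few compounds are considered here, and "the series" means these few. Any claim that something is new, unique, unknown or untested is made for them only; others in the source may bear on it.

compound 1 `C=C1CCC[C@]2(C)CCC(C=O)=CC[C@@]12C`: 734000 nM
compound 2 `C#CC1=CC[C@]2(CC1)C(=C)CC[C@H]2C(C)C`: 741000 nM
compound 3 `C=C1CCC[C@]2(C)CCC(c3cn(-c4cccc([N+](=O)[O-])c4)nn3)=CC[C@@]12C`: 699000 nM

All three were tested in an ADME assay on HEK293 cells (Homo sapiens) for cytotoxicity, read by MTT assay, with a stated time of 48 h; on this read-out higher numbers stand for weaker inhibition and lower numbers for stronger inhibition. Compound 3, at 699000 nM, lies within the usual scatter of both compound 1 and compound 2, so the three values cannot be told apart. Compound 4 `C=C1CCC[C@]2(C)CCC(c3cn(-c4ccc(Cl)cc4)nn3)=CC[C@@]12C` keeps the core of compound 3 but carries 4-chlorophenyl in place of 3-nitrophenyl on an aromatic nitrogen. For the measured compounds named here, no two measured compounds differ in just one place, so no measured step guides this swap. In this assay no step beyond the scatter is expected, because compound 2 gives 741000 nM despite a quite different structure. The estimated step is a 1.0-fold higher number from compound 3 to compound 4 (0.00 log units; within the scatter). Compound 4 is expected at 700000 nM, with an estimated range of 450000 nM to 1000000 nM.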

Compound 4, half-maximal inhibitory concentration: 609000 nM
Compound 4: the middle estimate sits 1.1-fold (0.06 log units) above what was measured, within the range that was stated.
By their numbers in this assay, from the lowest: compounds 4, 3, 1 and 2 (each within the scatter of the next).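

For the compounds shown here, this is the first pair here that differs in only one place: in this assay, putting 4-chlorophenyl in place of 3-nitrophenyl on the aromatic nitrogen gives a 1.1-fold lower number from compound 3 to compound 4 (0.06 log units; within the scatter). At this position, then, one substituted phenyl can replace another with no shift beyond the scatter, although the substituent and its place on the phenyl ring change together. Nothing measured here bears on the reason for this result.

Still open, on these data alone, is whether a phenyl ring bearing an amine or a carboxylic acid, or a longer alkyl chain in place of the ring, would give a number beyond the scatter.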